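The source may hold more compounds than are shown below. What is called first, only, known or untested is meant among the compounds shown, and "the series" means these compounds.

Three compounds built around a pyrazoline core carrying an indole and a pyridine carbonyl have been tested in a functional assay on A549 cells (Homo sapiens) for inhibition, read by MTT assay, with a stated time of 48 h; on this read-out lower numbers stand for stronger inhibition of growth and higher numbers for weaker inhibition of growth. Compound 1 `Cn1cc(C2CC(c3ccccc3)=NN2C(=O)c2cccnc2)c2ccccc21` reaches only the limit of this assay, > 10000 nM. That reading is the limit of > 10000 nM in this assay, at which 1 of the 3 values shown sits, so its true value is not known. Compound 2 `Cc1ccc(C(=O)N2N=C(c3ccccc3)CC2c2cn(C)c3ccccc23)cn1` differs from compound 1 by methyl in place of hydrogen on an aromatic carbon and in this assay compound 2 gives 1190 nM, a step of an at least 8.4-fold lower number from compound 1 to compound 2 (0.92 log units; beyond the scatter). Compound 3 `COc1cccc(C2=NN(C(=O)c3cccnc3)C(c3cn(C)c4ccc(OC)cc34)C2)c1` rests on a different core; the difference between the two cores is not broken down here. In this assay compound 3 gives 1020 nM, close to the value of compound 2. Going by the values given here, compound 4 `COc1cccc(C2=NN(C(=O)c3ccc(C)nc3)C(c3cn(C)c4ccc(OC)cc34)C2)c1` differs from compound 3 by methyl in place of hydrogen on an aromatic carbon, the same change as the one between compound 1 and compound 2. As far as these compounds go, because the earlier step of an at least 8.4-fold lower number from compound 1 to compound 2 (0.92 log units; beyond the scatter) starts from a limit, its real size is unknown, so a more cautious step is expected from compound 3 to compound 4, a 2.9-fold lower number from compound 3 to compound 4 (0.46 log units; beyond the scatter). Compound 4 is thus expected to give about 350 nM in this assay, most likely between 120 nM and 1000 nM.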

Compound 4, concentration for 50% growth inhibition: 590 nM
The estimate for compound 4 lay 1.7-fold (0.23 log units) below the measured number; low and high end bracket the measured number.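

In this assay, replacing pyridin-3-yl with 6-methylpyridin-3-yl on the second core gives a 1.7-fold lower number from compound 3 to compound 4 (0.24 log units; within the scatter), so on this core the methyl makes no difference that can be told from ordinary assay scatter. The same change on the core of compound 1 gave a much larger step, so it does not carry over at a fixed size from one core to the other: the same change on two cores in this assay, an at least 8.4-fold lower number (0.92 log units; beyond the scatter) from compound 1 to compound 2 and a 1.7-fold lower number (0.24 log units; within the scatter) from compound 3 to compound 4, at least 4.8-fold (0.68 log units) apart, beyond the scatter of two such steps Compound 1 gives a limit and not a number, so the true size of the earlier step is unknown, and these two pairs show only that the core matters, not which part of it does or why: the limit of > 10000 nM in this assay, at which 1 of the 4 values shown sits.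

The compounds shown leave open whether an ethyl group, an amine or a carboxylic acid at the same place would shift the number beyond the scatter on either core. They also leave open how the methyl would behave on a core that differs from the core of compound 1 in only one place.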